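A few compounds are considered here, and "the series" means these few. Any claim that something is new, unique, unknown or untested is made for them only; others in the source may bear on it.

Three analogues sharing one core have been tested in a functional assay on A549 cells (Homo sapiens) for antiproliferative activity, read by MTT assay, with a stated time of 72 h; a higher number here means a weaker inhibitor, a lower number a stronger inhibitor. Compound 1 `NS(=O)(=O)c1ccc(NC(=S)Nc2ccc3ncnc(Nc4cccc(C(F)(F)F)c4)c3c2)cc1` gives 10100 nM. Compound 2 `NS(=O)(=O)c1ccc(NC(=S)Nc2ccc3ncnc(Nc4cccc(Br)c4)c3c2)cc1` gives 25000 nM. Compound 3 `NS(=O)(=O)c1ccc(NC(=S)Nc2ccc3ncnc(Nc4ccc(C(F)(F)F)cc4)c3c2)cc1` reaches only > 40000 nM, which is a limit of this assay rather than a number, standing at the limit of > 40000 nM in this assay, at which 1 of the 3 values shown sits. Two measured steps lead into compound 3: an at least 3.9-fold higher number from compound 1 to compound 3 (0.59 log units; beyond the scatter) and an at least 1.6-fold higher number from compound 2 to compound 3 (0.20 log units; that floor lies within the scatter), while a 2.5-fold higher number from compound 1 to compound 2 (0.39 log units; beyond the scatter) separates the two 3-substituted analogues. Compound 4 `NS(=O)(=O)c1ccc(NC(=S)Nc2ccc3ncnc(Nc4cccc(Cl)c4)c3c2)cc1` differs from compound 3 by 3-chlorophenyl in place of 4-(trifluoromethyl)phenyl on a nitrogen on an aromatic ring. Since compound 2 with its 3-bromophenyl group gives 25000 nM, a return to a 3-chlorophenyl group is expected to lower the number. Compound 4 is therefore estimated at 22000 nM, with a range from 8000 nM to 60000 nM. That estimate corresponds to an expected at least 1.8-fold lower number from compound 3 to compound 4 (0.25 log units; that floor lies within the scatter).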

Compound 4, half-maximal inhibitory concentration: > 40000 nM
Compound 4 ended at the assay's limit; the forecaster's own chance of this, stated with the estimate: 25%; middle value at least 1.8-fold (0.25 log units) from the limit.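

Compound 4 reaches only a limit of the assay, not a number: the limit of > 40000 nM in this assay, at which 2 of the 4 values shown sit.

Chloro in place of trifluoromethyl brings an at least 3.9-fold higher number from compound 1 to compound 4 (0.59 log units; beyond the scatter), so a substituent at the 3-position of the phenyl group does not by itself keep a measured value. Chloro in place of bromo brings an at least 1.6-fold higher number from compound 2 to compound 4 (0.20 log units; that floor lies within the scatter), which gives that pair no firm order, and the step between the two limits cannot be read.

Still open, on these data alone, is how a 3-methoxyphenyl or 3-aminophenyl group on this nitrogen would read, and whether any group exceeds trifluoromethyl here.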